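Anilino-thiophene acids: methyl for methoxy on the benzoyl ring

A few compounds are considered here, and "the series" means these few. Any claim that something is new, unique, unknown or untested is made for them only; others in the source may bear on it.

In a functional assay, with a stated time of 150 min, tested at 20 ug/mL (a lower number here means a weaker effect, a higher number a stronger effect of the compound at the concentration tested), compound 1 `COc1ccc(C(=O)c2sc(Nc3ccccc3)c(C(=O)O)c2C)cc1` gives 41.2%, while compound 2 `COc1ccc(C(=O)c2sc(Nc3ccc(Cl)cc3)c(C(=O)O)c2C)cc1` is reported only as "not active" (no number reported), so compound 2 stands without a single number in this assay. Compound 3 `Cc1ccc(C(=O)c2sc(Nc3ccc(Cl)cc3)c(C(=O)O)c2C)cc1` has not been measured. Compound 3 differs from compound 2 by methyl in place of methoxy on an aromatic carbon. With no measured step of this kind in the series, no step beyond the usual scatter is expected in this assay in either direction. Compound 3 is therefore expected to give about 12%, with a range from 0% to 35%.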

Compound 3, a percentage reported as activity, at one concentration (the size of the read-out at that concentration, not a potency): "not active" (no number reported)
Nothing numeric was reported for compound 3, so the estimate cannot be set against anything.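

In this assay compound 2 and compound 3 are both reported only as not active, so no step can be read from methoxy to methyl. The compounds shown leave open whether this swap changes activity on a measurable background. No evidence bears on this result.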